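A Shared Core with Varied Substituents on the Ring Nitrogen

A few compounds are considered here, and "the series" means these few. Any claim that something is new, unique, unknown or untested is made for them only; others in the source may bear on it.

Three analogues built on one shared core were compared in a functional assay on PC-3 cells (Homo sapiens) for cytotoxicity, read by MTT assay, with a stated time of 72 h; on this read-out lower numbers stand for stronger inhibition and higher numbers for weaker inhibition. Compound 1 `CCCCCCNc1nc(SCc2ccc(C(F)(F)F)cc2)nc2ccccc12` carries a hexyl group on a nitrogen on an aromatic ring and gives 19000 nM. Compound 2 `CCOc1ccccc1Nc1nc(SCc2ccc(C(F)(F)F)cc2)nc2ccccc12` carries a 2-ethoxyphenyl group in that place and gives 26200 nM. Compound 3 `CCOc1ccc(Nc2nc(SCc3ccc(C(F)(F)F)cc3)nc3ccccc23)cc1` carries a 4-ethoxyphenyl group there and gives 32100 nM. Compound 3 has the highest of the three numbers, but its distance from compound 2 is a 1.2-fold higher number from compound 2 to compound 3 (0.09 log units; within the scatter) and from compound 1 is a 1.7-fold higher number from compound 1 to compound 3 (0.23 log units; within the scatter), so the three values cannot be told apart.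

Compound 4 `COc1ccc(Nc2nc(SCc3ccc(C(F)(F)F)cc3)nc3ccccc23)cc1OC` differs from compound 3 by 3,4-dimethoxyphenyl in place of 4-ethoxyphenyl on a nitrogen on an aromatic ring. Going by the values given here, the steps that bear on this change are those that exchanged the group on the same nitrogen: a 1.4-fold higher number from compound 1 to compound 2 (0.14 log units; within the scatter), a 1.7-fold higher number from compound 1 to compound 3 (0.23 log units; within the scatter) and a 1.2-fold higher number from compound 2 to compound 3 (0.09 log units; within the scatter). Among the compounds with values here, each of them stayed within the scatter, though none of them involved a 3,4-dimethoxyphenyl group, so the data give no direct precedent for this exact exchange. On that basis compound 4 is expected to remain close to compound 3, with an expected step of a 1.1-fold lower number from compound 3 to compound 4 (0.03 log units; within the scatter). The estimate for compound 4 in this assay is 30000 nM, with a range from 12000 nM to 75000 nM.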

Compound 4, half-maximal inhibitory concentration: 14100 nM
Compound 4: middle estimate off by 2.1-fold (0.33 log units), on the high side; the measured number falls inside the stated range.
By their numbers in this assay, from the lowest: compounds 4, 1, 2 and 3 (each within the scatter of the next, the first and the last beyond it).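

In this assay, going by these compounds alone, the exchange on this nitrogen produced the first step beyond the scatter: (a 2.3-fold lower number from compound 3 to compound 4 (0.36 log units; beyond the scatter)), a modest change with 3,4-dimethoxyphenyl in place of 4-ethoxyphenyl. The other two steps to the new group (a 1.9-fold lower number from compound 2 to compound 4 (0.27 log units; within the scatter); a 1.3-fold lower number from compound 1 to compound 4 (0.13 log units; within the scatter)) stay within the scatter, so the 3,4-dimethoxyphenyl group stands apart from the 4-ethoxyphenyl group but not from the 2-ethoxyphenyl or hexyl groups. The position therefore shows that it can respond to the choice of aryl group, even if only modestly, and no measurement available here accounts for this step.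

The exchange alters the alkoxy groups and the number of oxygens together, so the compounds shown cannot say whether the step follows the second oxygen or the shorter chains, a question that a 4-methoxyphenyl or 3-methoxyphenyl group on the same nitrogen would address. From the compounds shown here alone, it also remains open how this position would respond to a phenyl ring bearing a carboxylic acid or a dimethylamino group, or to a chain longer than hexyl.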